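The compounds below may be only part of what the source reports. "The series", "measured", "known", "first", "only" and "open" are said of these compounds alone.

In a functional assay on A549 cells (Homo sapiens) for cytotoxicity, read by MTT assay, with a stated time of 72 h (on this read-out lower numbers stand for stronger inhibition and higher numbers for weaker inhibition), compound 3 `COc1cc2c(Oc3ccc(NC(=O)c4cn(-c5ccccc5F)nn4)cc3F)ccnc2cc1OCCCN1CCC(C)CC1` gives 250 nM, the lowest of the three numbers recorded. Compound 1 `COc1cc2c(Oc3ccc(NC(=O)c4cn(-c5c(C)cccc5C)nn4)cc3F)ccnc2cc1OCCCN1CCCC1` gives 1240 nM in this assay, and compound 2 `COc1cc2c(Oc3ccc(NC(=O)c4cn(-c5ccccc5F)nn4)cc3F)ccnc2cc1OCCCN1CCCCC1` gives 2770 nM. Within the data shown here, the one step that can be read between two compounds differing in a single place is an 11-fold lower number from compound 2 to compound 3 (1.04 log units; beyond the scatter), a methyl in place of hydrogen on a saturated ring carbon. Compound 1 differs from compound 3 in more than one place, so its number tells nothing separate about either change.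

Compound 4 `COc1cc2c(Oc3ccc(NC(=O)c4cn(-c5ccc(F)c(F)c5)nn4)cc3F)ccnc2cc1OCCCN1CCC(C)CC1` differs from compound 3 by 3,4-difluorophenyl in place of 2-fluorophenyl on an aromatic nitrogen. Among the measured compounds shown here, no measured pair isolates a change on that aromatic nitrogen, so the step from compound 2 to compound 3, large as it was, does not bear on it directly; the saturated ring of compound 3 is kept unchanged in compound 4. For the measured compounds named here, with no step of this kind on record, the expectation is for a number close to that of compound 3, possibly with no step beyond the scatter in either direction. The estimated step is a 1.6-fold higher number from compound 3 to compound 4 (0.20 log units; within the scatter). Compound 4 is therefore expected to give 400 nM, with a range from 120 nM to 1300 nM.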

Compound 4, half-maximal inhibitory concentration: 1460 nM
For compound 4 the middle estimate is 3.7-fold (0.56 log units) below the measured one, outside the stated range (above it).
By their numbers in this assay, from the lowest: compound 3; then compounds 1, 4 and 2 (each within the scatter of the next, the first and the last beyond it).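

In this assay the aromatic nitrogen of the five-membered ring proves to be a position where the number responds to the group it carries: with the methyl-bearing saturated ring kept unchanged, 3,4-difluorophenyl in place of 2-fluorophenyl gives a 5.8-fold higher number from compound 3 to compound 4 (0.77 log units; beyond the scatter), a step beyond the scatter. Among these compounds, the earlier compounds offered no single-place comparison at this nitrogen, so this is the first reading of it, and it shows that the number depends on the aryl group here as well as on the methyl on the saturated ring. Nothing on record accounts for the rise in the number with this exchange.

The exchange removes the fluorine of 2-fluorophenyl and brings in those of 3,4-difluorophenyl at once, so the compounds shown leave open which of these changes carries the step, and a plain phenyl or a 4-fluorophenyl on the same nitrogen would be needed to separate them. Also open, from the compounds shown here alone, is whether the step would have the same size on the saturated ring without its methyl, as in compound 2.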